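A few compounds are considered here, and "the series" means these few. Any claim that something is new, unique, unknown or untested is made for them only; others in the source may bear on it.

In an assay on isolated protein for inhibition of Myeloperoxidase (Homo sapiens), with a stated time of 5 min (a lower number here means a stronger inhibitor, a higher number a weaker inhibitor), compound 2 `Cc1nc(N=C(N)N)nc2cc(F)ccc12` gives 40 nM, the higher of the two numbers in hand; compound 1 `NCCCCc1c[nH]c2ccc(F)cc12` gives 8 nM, a lower number, the gap lying beyond the scatter. Compound 3 `Cc1nc(N=C(N)N)nc2cc(Br)ccc12` differs from compound 2 by bromo in place of fluoro on an aromatic carbon. Within the data shown here, no measured pair shows this exchange, so the size of the step in this assay is open; a change within the scatter, or at most a small gain, is what is expected. Compound 3 is estimated at 25 nM, between 8 nM and 80 nM. The step of a 1.6-fold lower number from compound 2 to compound 3 (0.20 log units; within the scatter) that this estimate implies is expected to remain modest.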

Compound 3, half-maximal inhibitory concentration: 106 nM
For compound 3 the middle estimate is 4.2-fold (0.63 log units) below the measured one; measured number above the stated range.
By their numbers in this assay, from the lowest: compound 1; then compound 2; then compound 3.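

In this assay, bromo in place of fluoro on the aromatic carbon gives a 2.7-fold higher number from compound 2 to compound 3 (0.42 log units; beyond the scatter) and so shows that this position responds to the identity of the halogen, with fluoro the better of the two here. The exchange swaps one heavy atom for another, with no change in ring, hydrogen-bond donor or acceptor count, or net charge. Nothing in hand gives a reason for this step. Going by these compounds, whether chloro, a methoxy group or a nitrile at this place would match fluoro remains open, as does whether the same exchange would carry over to the core of compound 1.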